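Indole chalcone cytotoxicity notes: removing the benzyl group

The source may hold more compounds than are shown below. What is called first, only, known or untested is meant among the compounds shown, and "the series" means these compounds.

The series is built on a shared core carrying a nitrile and a carbonyl, with two fused bicyclic units on either side. Among the compounds with values here, compound 1 `COc1ccc(Cn2cc(/C=C(\C#N)C(=O)c3c[nH]c4cc(OC)ccc34)c3ccccc32)cc1` is the only member with a 4-methoxybenzyl group on an aromatic nitrogen. In a functional assay on A549 cells (Homo sapiens) for cytotoxicity, read by WST assay, with a stated time of 24 h (a higher number here means a weaker inhibitor, a lower number a stronger inhibitor), compound 1 gives 37400 nM, the highest of the two numbers obtained. Compound 3 `COc1ccc2[nH]cc(/C=C(\C#N)C(=O)c3c[nH]c4cc(F)ccc34)c2c1` gives 18000 nM in this assay, a lower number than compound 1 by a margin beyond the usual scatter. Compound 2 `N#C/C(=C\c1c[nH]c2cc(F)ccc12)C(=O)c1c[nH]c2cc(F)ccc12` reaches only the limit of this assay, > 50000 nM, and is reported as a limit rather than a number (the limit of > 50000 nM in this assay, at which 1 of the 3 values shown sits).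

Compound 4 `COc1ccc2c(C(=O)/C(C#N)=C/c3c[nH]c4ccccc34)c[nH]c2c1` is not yet measured. It differs from compound 1 in one place: hydrogen in place of 4-methoxybenzyl on an aromatic nitrogen. Within the data shown here, no measured pair in the set differs in exactly this way, so the direction of the step is open. Compound 3, which also carries a hydrogen on that aromatic nitrogen, gives 18000 nM in this assay. Compound 2, likewise with a hydrogen on that aromatic nitrogen, sits at a limit of this assay. Both weaker and comparable outcomes are thus on record among the members with a hydrogen on that nitrogen. The step from compound 1 to compound 4 is expected to be small, a 1.5-fold lower number from compound 1 to compound 4 (0.17 log units; within the scatter), with a modest lean towards a lower number. Compound 4 is therefore estimated at 25000 nM in this assay, within a range from 8000 nM to 70000 nM.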

Compound 4, half-maximal inhibitory concentration: 6400 nM
For compound 4 the middle estimate is 3.9-fold (0.59 log units) above the measured one, and the stated range ends above it.
By their numbers in this assay, from the lowest: compound 4; then compound 3; then compound 1. At a limit, above all of these: compound 2.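

In this assay, within the data shown here, the only pair that isolates this position gives a 5.8-fold lower number from compound 1 to compound 4 (0.77 log units; beyond the scatter), so hydrogen in place of 4-methoxybenzyl on an aromatic nitrogen lowers the number by more than the usual scatter. The 4-methoxybenzyl group, with its 9 heavy atoms and six-membered aromatic ring, is therefore not required for a low number in this pair, and its removal from the core of compound 1 does not leave the result unchanged. Compound 2 and compound 3 also carry hydrogen on that nitrogen but differ from compound 4 elsewhere, so they neither support nor contradict this step, and no measurement shown accounts for its size.

A single pair cannot show whether the lower number depends on removing the whole group or on its aromatic ring, and a methyl group, a longer alkyl chain or an unsubstituted benzyl group on that nitrogen would separate these readings. As far as these compounds go, whether the step persists when the other bicyclic unit carries fluorine in place of methoxy, or an amine or a carboxylic acid is added to the nitrogen substituent, also remains open.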